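The source may report more compounds than this note shows. Statements on the series, on what has been measured and on what is new or still open speak of the compounds shown alone.

Two compounds have been run so far, and a third is now in hand. Compound 1 `COc1ccc(-c2cc(/C=C/C(=O)c3ccc(N)cc3)[nH]n2)cc1` gives -87% in a functional assay on UO-31 cells (Homo sapiens) for cytotoxicity, read by sulforhodamine B assay, with a stated time of 48 h, tested at 100 uM; on this read-out lower numbers stand for a stronger effect and higher numbers for a weaker effect at the one concentration tested. Compound 2 `COc1cc(-c2cc(/C=C/C(=O)c3ccc(N)cc3)[nH]n2)cc(OC)c1OC` gives -93% in this assay, the lowest of the two numbers shown, though its gap to compound 1 lies within the scatter, so the two are not told apart on this read-out. Compound 3 `COc1ccc(-c2cc(/C=C/C(=O)c3ccc(N)cc3)[nH]n2)cc1OC` has not yet been measured in this assay. Against compound 2 it shows one difference: hydrogen in place of methoxy on an aromatic carbon. Going by the values given here, no step between measured compounds exists, so the size of this change cannot be read from any pair. The two measured values sit close together, and the expectation is that compound 3 stays in the same region, with a step of a number 5 percentage points higher from compound 2 to compound 3 (within the scatter) expected, none beyond the scatter. Compound 3 is estimated at -88% in this assay, within a range from -100% to -65%.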

Compound 3, a percentage reported as activity, at one concentration (the size of the read-out at that concentration, not a potency): -85%
The estimate for compound 3 lay 3 percentage points below the measured number; low and high end bracket the measured number.
By their numbers in this assay, from the lowest: compounds 2, 1 and 3 (each within the scatter of the next).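

Going by these compounds alone, both steps are the first that can be read, and both fall on the methoxy group of an aromatic carbon. In this assay, hydrogen in place of methoxy gives a number 8 percentage points higher from compound 2 to compound 3 (within the scatter), and methoxy in place of hydrogen gives a number 2 percentage points higher from compound 1 to compound 3 (within the scatter). With both steps inside the scatter, hydrogen and methoxy are not told apart on this carbon by this read-out, and nothing at hand offers an explanation for that.

From the compounds shown here alone, whether any group on this aromatic carbon can move the number beyond the scatter stays open, for example an amine, a carboxylic acid or a longer chain such as butoxy. The read-out comes from one concentration, so it shows only the size of the effect at that concentration, and compounds 1, 2 and 3 are not told apart by a stronger or weaker effect there.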